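The source may hold more compounds than are shown below. What is called first, only, known or untested is meant among the compounds shown, and "the series" means these compounds.

In an ADME assay on the whole organism (Rattus norvegicus, strain Sprague-Dawley) for pharmacokinetics, read by LC-MS, at a dose of 5 mg/kg by the oral route (a lower number here means less compound in the circulation, a higher number more compound in the circulation at the dose given), compound 3 (`Cc1nc(C)c([C@H](OC(C)(C)C)C(=O)O)c(N2CCC(C)(C)CC2)c1-c1ccc2c(c1)CCN(c1ncnc3c1cnn3C)C2`) stands highest of the three measured compounds at 22100 ng.h/mL. Compound 1 (`Cc1cccc(F)c1CN1CCc2cc(-c3c(C)nc(C)c([C@H](OC(C)(C)C)C(=O)O)c3N3CCC(C)(C)CC3)ccc2C1`) gives 9630 ng.h/mL and compound 2 (`Cc1nc(C)c([C@H](OC(C)(C)C)C(=O)O)c(N2CCC(C)(C)CC2)c1-c1ccc2c(c1)CCN(Cc1cccc(F)c1F)C2`) gives 5090 ng.h/mL, with a 1.9-fold lower number from compound 1 to compound 2 (0.28 log units; within the scatter). Compound 4 (`Cc1nc(C)c([C@H](OC(C)(C)C)C(=O)O)c(N2CCC(C)(C)CC2)c1-c1ccc2c(c1)CCN(c1nc3cnccc3s1)C2`) carries a group of 9 heavy atoms (6 carbon, 2 nitrogen, 1 sulfur; one five-membered aromatic ring with 2 hetero atoms, one six-membered aromatic ring with 1 hetero atom) in place of a group of 10 heavy atoms (6 carbon, 4 nitrogen; one five-membered aromatic ring with 2 hetero atoms, one six-membered aromatic ring with 2 hetero atoms), on an amine nitrogen in a ring. The nearest evidence is a 2.3-fold higher number from compound 1 to compound 3 (0.36 log units; beyond the scatter) and a 4.3-fold higher number from compound 2 to compound 3 (0.64 log units; beyond the scatter), both modest steps that put the group of compound 3 in place of a group with a carbon-only aromatic ring. Among the compounds with values here, no measured step exchanges one two-ring aromatic group for another, so a small downward drift, not beyond the scatter, is expected in this assay. The expected change is a 1.6-fold lower number from compound 3 to compound 4 (0.20 log units; within the scatter). For compound 4 the estimated value is 14000 ng.h/mL, with an expected range of 5500 ng.h/mL to 30000 ng.h/mL.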

Compound 4, area under the concentration-time curve: 6630 ng.h/mL
Compound 4: the middle estimate sits 2.1-fold (0.32 log units) above what was measured; the measured number falls inside the stated range.
By their numbers in this assay, from the lowest: compounds 2, 4 and 1 (each within the scatter of the next); then compound 3.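

At the amine nitrogen in a ring, two-ring aromatic groups do not form a single class in this assay: a 3.3-fold lower number from compound 3 to compound 4 (0.52 log units; beyond the scatter) is a modest step beyond the scatter. With a 1.3-fold higher number from compound 2 to compound 4 (0.11 log units; within the scatter) and a 1.5-fold lower number from compound 1 to compound 4 (0.16 log units; within the scatter) both within the scatter, the group of compound 4 stays level with the groups having a carbon-only aromatic ring. Having two aromatic rings in the group therefore does not by itself give the high number of compound 3. Open, on these data alone, is whether a single pyrimidine ring on the same nitrogen would keep that number. Nothing measured here accounts for the gap between compound 3 and compound 4.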